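This account rests on a few compounds, and the source may have more. Where it says the series, first, only, none or still open, it means among the compounds named here.

Measured compounds in an ADME assay on microsomes from liver (Homo sapiens) for metabolic stability, tested at 2.5 uM; on this read-out higher numbers stand for fast clearance and lower numbers for slow clearance:
compound 1 `O=S(=O)(c1ccc(F)cc1)c1cnc2cc(F)ccc2c1-c1ccc(F)cc1`: 1.34 mL/min
compound 2 `Cc1ccc(S(=O)(=O)c2cnc3cc(F)ccc3c2-c2ccc(F)cc2)cc1C`: 9.25 mL/min
compound 3 `COc1ccc(S(=O)(=O)c2cnc3cc(F)ccc3c2-c2ccc(F)cc2)cc1Cl`: 1.29 mL/min

Compound 2 gives the highest number of the three, and both of its steps lie beyond the scatter: a 6.9-fold higher number from compound 1 to compound 2 (0.84 log units; beyond the scatter) and a 7.2-fold lower number from compound 2 to compound 3 (0.86 log units; beyond the scatter). The remaining step, a 1.0-fold lower number from compound 1 to compound 3 (0.02 log units; within the scatter), is within the scatter.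

Compound 4 `Cc1ccc(S(=O)(=O)c2cnc3cc(F)ccc3c2-c2cccc(F)c2)cc1C` is not yet measured. Within the data shown here, it departs from compound 2 at a place none of the measured steps touch: 3-fluorophenyl in place of 4-fluorophenyl on an aromatic carbon. Every measured step alters the group on the sulfonyl sulfur, whereas the change to compound 4 keeps the 3,4-dimethylphenyl on the sulfonyl sulfur and alters the aryl on the aromatic carbon of the shared core. Among the measured compounds shown here, no measured step therefore bears directly on this change, and the series gives no guide to its direction. The two structures have the same atoms, joined differently, so the starting point is the number for compound 2. The working expectation is a step within the scatter, a 1.2-fold lower number from compound 2 to compound 4 (0.06 log units; within the scatter), with a wide range to reflect the absence of a matched step. Compound 4 is accordingly estimated at 8 mL/min, in a range from 3 mL/min to 20 mL/min.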

Compound 4, intrinsic clearance in a liver preparation (reported as CLH), per the amount of preparation that the assay uses: 3.71 mL/min
The estimate for compound 4 lay 2.2-fold (0.33 log units) above the measured number, within the range that was stated.
By their numbers in this assay, from the lowest: compounds 3 and 1 (each within the scatter of the next); then compound 4; then compound 2.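

In this assay, the aryl on the aromatic carbon of the shared core can shift the read-out by itself: with the 3,4-dimethylphenyl held on the sulfonyl sulfur, 3-fluorophenyl in place of 4-fluorophenyl gives a 2.5-fold lower number from compound 2 to compound 4 (0.40 log units; beyond the scatter). Among these compounds, the earlier steps all altered the group on the sulfonyl sulfur, so this is the first indication that the read-out also responds at this second place, and here to a change that only rearranges the same atoms. No available measurement accounts for the direction or size of this step.

On these data alone, this position rests on a single pair, so it remains open whether the same change would give a comparable step with 4-fluorophenyl or 3-chloro-4-methoxyphenyl on the sulfonyl sulfur, where compound 1 gives 1.34 mL/min and compound 3 gives 1.29 mL/min. Also open, as far as these compounds go, is how the read-out would respond to a different kind of group on this aryl, such as an amine or a carboxylic acid, or to a pyridine ring in place of the fluorophenyl.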